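Extending the Cyanopentyl Chain Toward a Chlorobenzyl Ether

A few compounds are considered here, and "the series" means these few. Any claim that something is new, unique, unknown or untested is made for them only; others in the source may bear on it.

Within the data shown here, compound 1 `CCCC[C@@H](C#N)NC(=O)[C@H](CC(C)C)NC(=O)N1CCOCC1` gives 56 nM in an assay for inhibition of cathepsin S (Homo sapiens) (a higher number here means a weaker inhibitor, a lower number a stronger inhibitor), and holds the lower of the two numbers known here. Among the measured compounds shown here, compound 2 `CC(C)C[C@H](NC(=O)N1CCOCC1)C(=O)NC(C)(C)C#N` gives 114 nM in this assay, the only measured step being a 2.0-fold higher number from compound 1 to compound 2 (0.31 log units; beyond the scatter). Compound 3 `CC(C)C[C@H](NC(=O)N1CCOCC1)C(=O)N[C@H](C#N)COCc1ccc(Cl)cc1` differs from compound 1 by (4-chlorobenzyl)oxy in place of propyl on a saturated chain carbon, two bonds along the chain from an amide-type nitrogen and a triple-bonded carbon. For the measured compounds named here, no measured step touches an exchange on the saturated chain carbon; the one known step concerns the substituents at the triple-bonded carbon and was modest. For compound 3 the expected step is therefore a 1.4-fold lower number from compound 1 to compound 3 (0.15 log units; within the scatter). The estimated value for compound 3 in this assay is 40 nM, within 10 nM to 160 nM.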

Compound 3, half-maximal inhibitory concentration: 27 nM
Estimate against measurement, compound 3: 1.5-fold (0.17 log units) above; the range from low to high includes it.
By their numbers in this assay, from the lowest: compound 3; then compound 1; then compound 2.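

In this assay, the saturated chain carbon, two bonds along the chain from an amide-type nitrogen and a triple-bonded carbon, accepts (4-chlorobenzyl)oxy in place of propyl with a 2.1-fold lower number from compound 1 to compound 3 (0.32 log units; beyond the scatter), a modest step. Among these compounds, the only earlier step concerned the substituents at the triple-bonded carbon, so this is the first reading at this position, and here the larger group with its aromatic ring goes with the lower number. No evidence at hand accounts for this step.

From the compounds shown here alone, the exchange brings in the ring, the ether oxygen and the chlorine together, so their separate shares remain open. Going by these compounds, how a benzyloxy group without the chlorine, or an amine on the same chain, would stand also remains open.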